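A few compounds are considered here, and "the series" means these few. Any claim that something is new, unique, unknown or untested is made for them only; others in the source may bear on it.

Compound 1 `CCCC[S+]([O-])c1sc2nc(-c3nccs3)cc(-c3ccc(C(C)(C)O)cc3)c2c1N` and compound 2 `CCCC[S+]([O-])c1sc2nc(-c3nccs3)cc(-c3ccc(COC(=O)NCC)cc3)c2c1N` share one core and differ only in the group on the phenyl ring. In an assay for inhibition of 15-hydroxyprostaglandin dehydrogenase [NAD(+)] (Homo sapiens), read by fluorescence, with a stated time of 15 min, in the presence of a further agent that is not named here (on this read-out higher numbers stand for weaker inhibition and lower numbers for stronger inhibition), compound 1 gives 3.6 nM, the higher of the two numbers shown, and compound 2 gives 3.4 nM; the step of a 1.1-fold lower number from compound 1 to compound 2 (0.02 log units; within the scatter) is small. Compound 3 `CCCC[S+]([O-])c1sc2nc(-c3nccs3)cc(-c3cnc(C)[nH]3)c2c1N` carries 2-methyl-1H-imidazol-5-yl in place of 4-(1-hydroxy-1-methylethyl)phenyl on an aromatic carbon. Among the measured compounds shown here, the single measured step only swaps one group on a phenyl ring that here disappears altogether, so it says little about this change. For compound 3 the estimate is 10 nM in this assay, within 2 nM to 60 nM, an expected step of a 2.8-fold higher number from compound 1 to compound 3 (0.44 log units; beyond the scatter).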

Compound 3, half-maximal inhibitory concentration: 2.3 nM
Compound 3: middle estimate off by 4.3-fold (0.64 log units), on the high side; the range from low to high includes it.
By their numbers in this assay, from the lowest: compounds 3, 2 and 1 (each within the scatter of the next).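

In this assay, the step for putting 2-methyl-1H-imidazol-5-yl in place of 4-(1-hydroxy-1-methylethyl)phenyl is a 1.6-fold lower number from compound 1 to compound 3 (0.19 log units; within the scatter), so this position accepts the loss of the whole six-membered carbon ring, not only a change to the group on it. The entering five-membered ring with 2 hetero atoms has 6 heavy atoms, fewer than the group that leaves, and the number stays within the scatter. Nothing available explains this tolerance. 

On these data alone, whether this position needs an aromatic ring at all remains open. An open-chain amine or a carboxylic acid placed there would test this, and an imidazole lacking the methyl group would show what that methyl contributes.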